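A few compounds are considered here, and "the series" means these few. Any claim that something is new, unique, unknown or untested is made for them only; others in the source may bear on it.

In a toxicity assay on L02 cells (Homo sapiens) for cytotoxicity, read by MTT assay, with a stated time of 72 h (on this read-out higher numbers stand for weaker inhibition and lower numbers for stronger inhibition), compound 1 `O=C1c2c[n+]([O-])c3ccccc3c2C(=O)c2c1c1ccccc1n2Cc1cn([C@@H]2C[C@H](O)[C@@H](CO)O2)nn1` gives 630 nM and compound 2 `O=C1c2c[n+]([O-])c3ccccc3c2C(=O)c2c1c1ccccc1n2Cc1cn(C[C@H](O)CO)nn1` gives 1130 nM. Among the compounds with values here, these are the only two numbers so far, and they lie within the usual scatter of each other, so compound 2 cannot be ranked apart from compound 1. Compound 3 `CC1(C)OCC(Cn2cc(Cn3c4c(c5ccccc53)C(=O)c3c[n+]([O-])c5ccccc5c3C4=O)nn2)O1` keeps the shared core of compound 2 and differs in one place: 2,2-dimethyl-1,3-dioxolan-4-yl in place of 1,2-dihydroxyethyl on a saturated chain carbon bound to an aromatic nitrogen. Cut one bond further out, the same difference reads 2,3-dihydroxypropyl to (2,2-dimethyl-1,3-dioxolan-4-yl)methyl, on a group bound to an aromatic nitrogen. Within the data shown here, the one measured step that bears on this is a 1.8-fold higher number from compound 1 to compound 2 (0.25 log units; within the scatter), a swap of the group on an aromatic nitrogen with the shared core untouched. It is a different swap from the one here, so it serves only as a loose guide, and no direction can be favoured. On that single step, no change beyond the scatter is expected in this assay. The expected step is a 1.1-fold lower number from compound 2 to compound 3 (0.05 log units; within the scatter). For compound 3 the estimated value is 1000 nM, within an expected range of 350 nM to 3000 nM.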

Compound 3, half-maximal inhibitory concentration: 120 nM
Beside the measured number, compound 3's estimate is 8.3-fold (0.92 log units) above it; measured number outside the range, below it.
By their numbers in this assay, from the lowest: compound 3; then compounds 1 and 2 (each within the scatter of the next).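

In this assay, the change from 1,2-dihydroxyethyl to 2,2-dimethyl-1,3-dioxolan-4-yl on a saturated chain carbon bound to an aromatic nitrogen gives a 9.4-fold lower number from compound 2 to compound 3 (0.97 log units; beyond the scatter), so this part of the molecule can shift the result beyond the scatter, which the earlier pair of compound 1 and compound 2 could not show. The same holds against the larger 4-hydroxy-5-(hydroxymethyl)oxolan-2-yl group, with a 5.3-fold lower number from compound 1 to compound 3 (0.72 log units; beyond the scatter), so the result with the (2,2-dimethyl-1,3-dioxolan-4-yl)methyl group stands apart from both compounds that carry free hydroxyl groups. Nothing measured here explains why the number falls.

The change does several things at once: the hydrogen-bond donors go from 2 to 0, a five-membered non-aromatic ring appears, and the heavy atoms go from 4 to 7, so the compounds shown cannot say which of these matters. A 1,3-dioxolane without the two methyl groups, a 2,3-dimethoxypropyl chain or an amine at this place would help to separate these features, and the shown compounds also leave open whether the drop extends to other ring sizes.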